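The source may report more compounds than this note shows. Statements on the series, on what has been measured and on what is new or still open speak of the compounds shown alone.

Measured so far in an ADME assay on cells (Peritoneal macrophage, Mus musculus, strain Balb/c) for cytotoxicity, read by resazurin assay, with a stated time of 72 h; on this read-out lower numbers stand for higher toxicity in this test and higher numbers for lower toxicity in this test:
compound 1, `CC1(Cc2ccccc2)CC(S(=O)(=O)c2ccc(F)cc2)=C(c2ccc(/C(N)=N/O)cc2)O1`, gives 102000 nM
compound 2, `CC1(Cc2ccc(/C(N)=N/O)cc2)CC(S(=O)(=O)c2ccc(F)cc2)=C(c2ccc(/C(N)=N/O)cc2)O1`, gives 42200 nM

Among the compounds with values here, compound 2 holds the lowest of the two numbers in this assay; the only step known, a 2.4-fold lower number from compound 1 to compound 2 (0.38 log units; beyond the scatter), is a modest drop in the number on adding the group to an aromatic carbon. Compound 3, `CC1(Cc2cccc(/C(N)=N/O)c2)CC(S(=O)(=O)c2ccc(F)cc2)=C(c2ccc(/C(N)=N/O)cc2)O1`, keeps the same atoms as compound 2 and differs only in how they are joined: a group of 10 heavy atoms (7 carbon, 2 nitrogen, 1 oxygen; one six-membered aromatic ring of carbon only) in place of a group of 10 heavy atoms (7 carbon, 2 nitrogen, 1 oxygen; one six-membered aromatic ring of carbon only), on a saturated chain carbon bound to a saturated ring carbon. Within the data shown here, no measured step bears on this rearrangement. Among the measured compounds shown here, the single step known concerns the presence of the group rather than where it sits on its ring, and that step was itself modest. With nothing in the data that speaks for a shift in either direction, no step beyond the scatter is expected from compound 2 to compound 3 in this assay. The expected step is accordingly a 1.1-fold higher number from compound 2 to compound 3 (0.03 log units; within the scatter), which is no change beyond the scatter. Compound 3 is therefore estimated at 45000 nM in this assay, with a range from 18000 nM to 110000 nM. For the measured compounds named here, the range is kept wide because the one known step of a 2.4-fold lower number from compound 1 to compound 2 (0.38 log units; beyond the scatter) gives no guide to how the placement of the group on its ring matters.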

Compound 3, half-maximal cytotoxic concentration: 50200 nM
Beside the measured number, compound 3's estimate is 1.1-fold (0.05 log units) below it; the measured number falls inside the stated range.
By their numbers in this assay, from the lowest: compounds 2 and 3 (each within the scatter of the next); then compound 1.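

In this assay, rearranging the group of 10 heavy atoms on a saturated chain carbon bound to a saturated ring carbon gives a 1.2-fold higher number from compound 2 to compound 3 (0.08 log units; within the scatter), so this change of arrangement has no effect beyond the scatter between these two compounds. Adding the group of 4 heavy atoms to an aromatic carbon now gives a lower number in both arrangements, with a 2.0-fold lower number from compound 1 to compound 3 (0.31 log units; beyond the scatter) alongside a 2.4-fold lower number from compound 1 to compound 2 (0.38 log units; beyond the scatter); among these compounds the number therefore tracks the presence of the added group rather than the difference between compound 2 and compound 3, and neither goes against that reading. No supporting evidence is available to explain these numbers.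

As far as these compounds go, it remains open whether an amine or a carboxylic acid in place of the added group would lower the number to a similar extent, or whether such a group would leave it within the scatter of compound 1. From the compounds shown here alone, it also remains open whether a longer chain at the saturated chain carbon bound to a saturated ring carbon would change the number.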